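From dimethylamino to methyl on a shared core

This account rests on a few compounds, and the source may have more. Where it says the series, first, only, none or still open, it means among the compounds named here.

Measured in a functional assay on HT-29 cells (Homo sapiens) for antiproliferative activity, read by MTT assay, with a stated time of 72 h (on this read-out lower numbers stand for stronger inhibition and higher numbers for weaker inhibition), so far
compound 1 `CNc1nc(-c2cc(OC)c(OC)c(OC)c2)c(-c2ccc3ccccc3c2)s1` gives 38.2 nM
compound 2 `COc1cc(-c2nc(N(C)C)sc2-c2ccc3ccccc3c2)cc(OC)c1OC` gives 729 nM
compound 3 `COc1cc(-c2nc(N(C)C)sc2-c2ccc(C(F)(F)F)cc2)cc(OC)c1OC` gives > 10000 nM

Compound 3 stands at > 10000 nM as a limit of the assay and not as a number. Compound 2, at 729 nM, has the higher of the two true numbers, and compound 1 is its nearest neighbour.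

Compound 4 `COc1cc(-c2nc(C)sc2-c2ccc3ccccc3c2)cc(OC)c1OC` keeps the naphthalen-2-yl group of compound 2 and carries methyl in place of dimethylamino on an aromatic carbon, next to the ring nitrogen and next to the ring sulfur (methyl in place of dimethylamino on an aromatic carbon).

For the measured compounds named here, two measured steps bear on this change. The closer one is a 19-fold higher number from compound 1 to compound 2 (1.28 log units; beyond the scatter), a large step made at the same place, which shows that this assay responds strongly to the group there. The other is an at least 13-fold higher number from compound 2 to compound 3 (1.13 log units; beyond the scatter), also large, but it concerns the naphthalen-2-yl group that compound 4 retains, so it gives no direction here. Going by the values given here, no measured compound carries methyl at this place, so the direction stays open and the expected size is uncertain. The expected step is a 1.5-fold lower number from compound 2 to compound 4 (0.16 log units; within the scatter), which would be no clear shift beyond the scatter. Compound 4 is estimated at 500 nM, with an expected range from 60 nM to 4000 nM in this assay.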

Compound 4, half-maximal inhibitory concentration: 702 nM
The estimate for compound 4 lay 1.4-fold (0.15 log units) below the measured number; measured number inside the range.
By their numbers in this assay, from the lowest: compound 1; then compounds 4 and 2 (each within the scatter of the next). At a limit, above all of these: compound 3.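

In this assay, this position does not separate dimethylamino from methyl: the change is a 1.0-fold lower number from compound 2 to compound 4 (0.02 log units; within the scatter), although the two groups differ in size and in hydrogen-bond acceptor count. The position is still not indifferent, as the methylamino group of compound 1 stands apart from both, with an 18-fold higher number from compound 1 to compound 4 (1.26 log units; beyond the scatter), a step much like a 19-fold higher number from compound 1 to compound 2 (1.28 log units; beyond the scatter). So the large response seen earlier at this place now looks tied to methylamino specifically, not to any departure from dimethylamino, though the data shown offer no explanation for this pattern.

Going by these compounds, whether the hydrogen on the nitrogen of methylamino is what matters remains open, and a primary amine or an ethylamino group at this place would bear on that question, as would a methoxy group, which has oxygen where methylamino has nitrogen. On these data alone, it is also open whether methylamino would keep its advantage over methyl and dimethylamino with 4-(trifluoromethyl)phenyl in place of naphthalen-2-yl, as the three-way comparison rests on the naphthalen-2-yl series alone.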